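The source may hold more compounds than are shown below. What is called first, only, known or untested is meant among the compounds shown, and "the series" means these compounds.

Compound 1, `C[C@H]1[C@H](O)C[C@@H](CCO)N[C@H]1c1ccccc1`, and compound 2, `C[C@H]1[C@H](O)C[C@@H](CC(=O)O)N[C@H]1c1ccccc1`, share a core and differ in a single spot: carboxy in place of hydroxymethyl on a saturated chain carbon bound to a saturated ring carbon. In a functional assay on A549 cells (Homo sapiens) for cytotoxicity, read by MTT assay (on this read-out lower numbers stand for stronger inhibition and higher numbers for weaker inhibition), compound 1 gives 31200 nM, and compound 2 gives 28900 nM. That exchange made a 1.1-fold lower number from compound 1 to compound 2 (0.03 log units; within the scatter), so the two numbers cannot be told apart by this kind of measurement. Compound 3, `COc1ccc([C@H]2N[C@@H](CCO)C[C@H](O)[C@H]2C)cc1`, carries the same hydroxymethyl-bearing side chain on a core that differs from the core of compound 1; the difference between the two cores is not broken down here. In this assay compound 3 gives 17600 nM, a number that sits within the scatter of both compound 1 and compound 2, so no ordering among the three can be read from it. Compound 4, `COc1ccc([C@H]2N[C@@H](CC(=O)O)C[C@H](O)[C@H]2C)cc1`, has not yet been measured. It stands to compound 3 as compound 2 stands to compound 1: carboxy in place of hydroxymethyl on a saturated chain carbon bound to a saturated ring carbon, the same change at the same place, a saturated chain carbon bound to a saturated ring carbon. Because the earlier exchange made a 1.1-fold lower number from compound 1 to compound 2 (0.03 log units; within the scatter), the step expected now is a 1.1-fold lower number from compound 3 to compound 4 (0.04 log units; within the scatter), resting on that single precedent and nothing more. On that basis compound 4 is expected to give about 16000 nM in this assay, with the estimate most likely falling between 8000 nM and 32000 nM.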

Compound 4, half-maximal inhibitory concentration: 20100 nM
The estimate for compound 4 lay 1.3-fold (0.10 log units) below the measured number; measured number inside the range.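

In this assay, putting carboxy in place of hydroxymethyl on the second core gave a 1.1-fold higher number from compound 3 to compound 4 (0.06 log units; within the scatter), so this exchange produced no change that this kind of measurement can detect. Set beside the earlier case, the same exchange reads alike on the two cores, and the two steps cannot be told apart: the same change on two cores in this assay, a 1.1-fold lower number (0.03 log units; within the scatter) from compound 1 to compound 2 and a 1.1-fold higher number (0.06 log units; within the scatter) from compound 3 to compound 4, 1.2-fold (0.09 log units) apart, within the scatter of two such steps. For the compounds shown here, this shows that, for these two cores in this one cell assay, going from 2-hydroxyethyl to carboxymethyl left the number within the scatter both times, but it does not show that the result would hold on any other core, and with only two flat steps, it says nothing about whether a clear gain or loss would carry from one core to another.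

The compounds shown leave open whether a different group at this place, on a saturated chain carbon bound to a saturated ring carbon, such as an amine, an amide or a longer chain, would move the number beyond the scatter. They also leave open whether the exchange would stay just as flat in another kind of cell.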